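The source may hold more compounds than are shown below. What is called first, only, known or untested is meant among the compounds shown, and "the series" means these compounds.

Compound 3 `CC1=CC[C@@H]([C@@](C)(O)CCCC(C)(C)NC(=S)N/N=C\c2cccc([N+](=O)[O-])c2)CC1` gives the lowest of the three numbers in a functional assay on PCO3 cells (Homo sapiens) for cytotoxicity, read by sulforhodamine B assay (on this read-out higher numbers stand for weaker inhibition of growth and lower numbers for stronger inhibition of growth), at 5600 nM. Compound 1 `COc1ccc(/C=N\NC(=S)NC(C)(C)CCC[C@](C)(O)[C@@H]2CC=C(C)CC2)cc1`, with 7660 nM, sits nearest, and a 1.4-fold lower number from compound 1 to compound 3 (0.14 log units; within the scatter). Compound 2 `CC1=CC[C@@H]([C@@](C)(O)CCCC(C)(C)NC(=S)N/N=C\c2ccccc2[N+](=O)[O-])CC1`, with 39900 nM, is furthest away, as a 7.1-fold lower number from compound 2 to compound 3 (0.85 log units; beyond the scatter). The next compound, compound 4 `CC1=CC[C@@H]([C@@](C)(O)CCCC(C)(C)NC(=S)N/N=C\c2ccccc2Cl)CC1`, arises from compound 3 through a single change: 2-chlorophenyl in place of 3-nitrophenyl on a carbon with a double bond to nitrogen. Among the measured compounds shown here, two measured steps bear on this. Moving the nitro group from the 3-position to the 2-position gave a 7.1-fold lower number from compound 2 to compound 3 (0.85 log units; beyond the scatter) in reverse, and placing a 2-nitrophenyl in place of a 4-methoxyphenyl gave a 5.2-fold higher number from compound 1 to compound 2 (0.72 log units; beyond the scatter). Both point to a higher number when the group sits at the 2-position, so a modest rise beyond the scatter is expected for compound 4 in this assay: a 3.2-fold higher number from compound 3 to compound 4 (0.51 log units; beyond the scatter). Compound 4 is therefore estimated at 18000 nM, within a range of 7000 nM to 45000 nM.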

Compound 4, concentration for 50% growth inhibition: 18800 nM
Compound 4: middle estimate off by 1.0-fold (0.02 log units), on the low side; measured number inside the range.
By their numbers in this assay, from the lowest: compounds 3 and 1 (each within the scatter of the next); then compound 4; then compound 2.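

In this assay, compound 4 shows that a higher number is not confined to 2-nitrophenyl: 2-chlorophenyl also gives a 3.4-fold higher number from compound 3 to compound 4 (0.53 log units; beyond the scatter) and a 2.5-fold higher number from compound 1 to compound 4 (0.39 log units; beyond the scatter). The group on the ring still matters, since chloro in place of nitro gives a 2.1-fold lower number from compound 2 to compound 4 (0.33 log units; beyond the scatter). No measurement at hand accounts for these steps. The compounds shown leave open how an amine, a methyl or a carboxylic acid in place of the chloro of 2-chlorophenyl would behave, and whether such groups would follow the same order.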